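Swapping the Sulfonamide Amine in a Cyclic Ether Scaffold

The compounds below may be only part of what the source reports. "The series", "measured", "known", "first", "only" and "open" are said of these compounds alone.

Two compounds built on a shared core, compound 1 `COc1cccc(N(C)S(=O)(=O)C2CC3OC2C(c2ccc(NC(=O)CCCCCCC(=O)O)cc2)=C3c2ccc(O)cc2)c1` and compound 2 `CCN(c1ccc(O)cc1)S(=O)(=O)C1CC2OC1C(c1ccc(NC(=O)CCCCCCC(=O)O)cc1)=C2c1ccc(O)cc1`, have been tested in a functional assay on MCF7 cells (Homo sapiens) for antiproliferative activity, read by MTT assay, with a stated time of 72 h; on this read-out higher numbers stand for weaker inhibition and lower numbers for stronger inhibition. In this assay compound 1 gives 39400 nM, and compound 2 gives 46600 nM. For the measured compounds named here, the only step between them, a 1.2-fold higher number from compound 1 to compound 2 (0.07 log units; within the scatter), leaves the two numbers within the scatter of each other, so neither can be ranked against the other. Compound 3 `CCN(c1ccc(Cl)cc1)S(=O)(=O)C1CC2OC1C(c1ccc(NC(=O)CCCCCCC(=O)O)cc1)=C2c1ccc(O)cc1` has not yet been measured. It differs from compound 1 in one place: (4-chlorophenyl)(ethyl)amino in place of (3-methoxyphenyl)(methyl)amino on a sulfonyl sulfur. Going by the values given here, the one measured step that bears on it, a 1.2-fold higher number from compound 1 to compound 2 (0.07 log units; within the scatter), also replaced the amine on the sulfonyl sulfur and moved the number only within the scatter. On that basis no step beyond the scatter is expected here either, in either direction. Compound 3 is therefore expected to give 40000 nM, with a range from 15000 nM to 110000 nM. The expected step is a 1.0-fold higher number from compound 1 to compound 3 (0.01 log units; within the scatter).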

Compound 3, half-maximal inhibitory concentration: 22100 nM
Estimate against measurement, compound 3: 1.8-fold (0.26 log units) above, within the range that was stated.
By their numbers in this assay, from the lowest: compounds 3, 1 and 2 (each within the scatter of the next, the first and the last beyond it).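

In this assay, for the compounds shown here, a change on the aryl group of the amine on the sulfonyl sulfur gives the first step beyond the scatter: chloro in place of hydroxy on an aromatic carbon is a modest step (a 2.1-fold lower number from compound 2 to compound 3 (0.32 log units; beyond the scatter)). Going by these compounds alone, the exchange of (3-methoxyphenyl)(methyl)amino for (4-chlorophenyl)(ethyl)amino stays within the scatter (a 1.8-fold lower number from compound 1 to compound 3 (0.25 log units; within the scatter)), so compound 3 cannot be ranked against compound 1, and only the pair differing in chloro and hydroxy separates. Nothing available accounts for that separation.

As far as these compounds go, whether bromo or methyl on that aromatic carbon would behave as chloro does remains open, as does the outcome of a saturated amine such as piperidine on the sulfonyl sulfur. Methyl and ethyl on the nitrogen are also never compared with the aryl group held fixed.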